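Hydroxy in Place of Chloro on an Inactive Series

The compounds below may be only part of what the source reports. "The series", "measured", "known", "first", "only" and "open" are said of these compounds alone.

Compound 1 `CCOC(=O)c1cnc2n(c1=O)C(C)CC/C2=N\Nc1ccccc1` was tested in a functional assay on the whole organism for inhibition, with Rattus norvegicus as the target (a higher number here means that more compound is needed for the effect, a lower number that less compound is needed), and gave only a limit, > 1000 umol/kg. Compound 2 `CC1CC/C(=N\Nc2ccccc2)c2ncc(C(=O)NN)c(=O)n21` likewise gave only a limit in this assay, > 1000 umol/kg. The step that the two limits leave unreadable from compound 1 to compound 2 is thus unreadable. Compound 3 `CC1CC/C(=N\Nc2ccccc2Cl)c2ncc(C(=O)O)c(=O)n21` also reached only a limit in this assay, > 1000 umol/kg, so it stands where the other two stand, as the limit of > 1000 umol/kg in this assay, at which 3 of the 3 values shown sit, records. Compound 4 `CC1CC/C(=N\Nc2ccccc2O)c2ncc(C(=O)O)c(=O)n21` differs from compound 3 by hydroxy in place of chloro on an aromatic carbon. Among the measured compounds shown here, no measured step bears on this change, and none of the three measured compounds yields a number; nothing here points to a move beyond the scatter in either direction. Compound 4 is therefore expected near 1500 umol/kg, between 400 umol/kg and 6000 umol/kg, most likely again as a limit. The implied step, a step that the limit leaves unreadable from compound 3 to compound 4, is expected to lie within the scatter.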

Compound 4, dose for 50% inhibition: > 100 umol/kg
Compound 4: no number, only a limit; the forecaster's own chance of this, stated with the estimate: 80%; the middle value is on the limit's open side.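

Among the compounds shown here, compound 3 and compound 4 each gave only a limit in this assay, so no step between them can be read. The compounds shown leave open whether hydroxy in place of chloro changes the dose needed at all.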